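Aroyl amide variation on the shared core

A few compounds are considered here, and "the series" means these few. Any claim that something is new, unique, unknown or untested is made for them only; others in the source may bear on it.

Compound 1 `O=C(Nc1ccc(Br)cc1CN1C(=O)c2ccccc2C1=O)c1ccccn1` gives < 1000 nM in an assay on CHO cells for positive allosteric modulation of metabotropic glutamate receptor 5 (Rattus norvegicus), read by FLIPR; on this read-out higher numbers stand for an effect only at larger amounts of compound and lower numbers for an effect already at smaller amounts; this is a limit of the assay, not a number.
Compound 2 `O=C(Nc1ccc(Cl)cc1CN1C(=O)c2ccccc2C1=O)c1ccco1` gives < 1000 nM in this assay; again only a limit.
Compound 3 `O=C(Nc1ccc(Cl)cc1CN1C(=O)c2ccccc2C1=O)c1ncccn1` gives < 1000 nM in this assay; again only a limit.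

Compound 2 stands only at a limit, and so do the other two values, all three sitting at the limit of < 1000 nM in this assay, at which 3 of the 3 values shown sit. Within the data shown here, the one step between measured compounds that differ in a single place, a step that the two limits leave unreadable from compound 2 to compound 3, therefore cannot be sized from the two limits.

Compound 4 `O=C(Nc1ccc(Cl)cc1CN1C(=O)c2ccccc2C1=O)c1cccnn1` is not yet measured. It differs from compound 2 by pyridazin-3-yl in place of furan-2-yl on a carbonyl carbon. Among the measured compounds shown here, the only step that bears on this change is the one from compound 2 to compound 3, which is unreadable, so no direction or size beyond the scatter can be taken from it for this assay. The expectation is that compound 4 also lands at the limit, and the step that the limit leaves unreadable from compound 2 to compound 4 is estimated as nothing readable. Compound 4 is expected at 300 nM, in the range 40 nM to 1500 nM.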

Compound 4, half-maximal effective concentration: < 1000 nM
Compound 4: only a limit was reported (the forecaster's own chance of this, stated with the estimate: 70%); the middle value does not contradict the limit.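

With compound 4 also reported only as a limit, the steps to compound 4 from compound 2 and from compound 3 cannot be read: the limit of < 1000 nM in this assay, at which 4 of the 4 values shown sit.

Whether furan-2-yl, pyrimidin-2-yl and pyridazin-3-yl on the carbonyl carbon differ at all in this assay remains open, as does the true potency of each compound shown.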